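The compounds below may be only part of what the source reports. "The series", "measured", "known", "first", "only" and "open" are said of these compounds alone.

Compound 1 `O=C1c2c[n+]([O-])c3ccccc3c2C(=O)c2c1c1ccccc1n2Cc1cn([C@H]2O[C@H](CO)[C@@H](O)[C@H]2O)nn1`: 1370 nM
Compound 2 `O=C1c2c[n+]([O-])c3ccccc3c2C(=O)c2c1c1ccccc1n2Cc1cn([C@@H]2C[C@H](O)[C@@H](CO)O2)nn1`: 820 nM
Compound 3 `CN1CCN(CCCCn2c3c(c4ccccc42)C(=O)c2c[n+]([O-])c4ccccc4c2C3=O)CC1`: 100 nM

In a toxicity assay on HEK-293T cells (Homo sapiens) for cytotoxicity, read by MTT assay, with a stated time of 72 h (a higher number here means a weaker inhibitor, a lower number a stronger inhibitor), compound 3 has the lowest number of the three at 100 nM, well clear of compound 2 at 820 nM and compound 1 at 1370 nM. Compound 4 `O=C1c2c[n+]([O-])c3ccccc3c2C(=O)c2c1c1ccccc1n2CCCN1CCC(O)CC1` keeps the shared core but differs from compound 3 in its side chain: 4-hydroxypiperidin-1-yl in place of (4-methylpiperazin-1-yl)methyl on a saturated chain carbon, three bonds along the chain from an aromatic nitrogen.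

For the measured compounds named here, the only measured step involving a hydroxy group is a 1.7-fold lower number from compound 1 to compound 2 (0.22 log units; within the scatter), with hydrogen in place of hydroxy on a saturated ring carbon. That step lies within the scatter, and it sits on a different side chain, so it offers only weak guidance. Going by the values given here, no measured compound carries the 4-hydroxypiperidin-1-yl group. Among the compounds with values here, compound 3 at 100 nM is the lowest number so far, so a moderate rise in this assay seems more likely than a further fall, though the uncertainty is wide. The expected step is a 2.5-fold higher number from compound 3 to compound 4 (0.40 log units; beyond the scatter). The estimate for compound 4 is 250 nM, with an expected range of 70 nM to 900 nM.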

Compound 4, half-maximal inhibitory concentration: 170 nM
The estimate for compound 4 lay 1.5-fold (0.17 log units) above the measured number; low and high end bracket the measured number.
By their numbers in this assay, from the lowest: compounds 3 and 4 (each within the scatter of the next); then compounds 2 and 1 (each within the scatter of the next).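

In this assay, the change of 4-(4-methylpiperazin-1-yl)butyl to 3-(4-hydroxypiperidin-1-yl)propyl gives a 1.7-fold higher number from compound 3 to compound 4 (0.23 log units; within the scatter), so the two side chains cannot be told apart here. This shows that the low number of compound 3 does not belong to the 4-methylpiperazin-1-yl ring alone: a different ring carrying a hydroxy group, on a propyl rather than a butyl chain, gives a value within the scatter of it. No measurement shown explains this result.

Chain length, ring and hydroxy group all change in this one step, so what each contributes on its own remains open. A piperidine without the hydroxy group, a morpholine ring, or a carboxylic acid in place of the ring could each help to separate these contributions.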